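A few compounds are considered here, and "the series" means these few. Any claim that something is new, unique, unknown or untested is made for them only; others in the source may bear on it.

Measured compounds:
Compound 1 `O=C(NNC(=O)c1ccccc1Cl)c1cccc(NS(=O)(=O)c2cnc(O)nc2O)c1` gives 2360 nM in a functional assay on MDA-MB-231 cells (Homo sapiens) for antiproliferative activity, read by MTT assay, with a stated time of 24 h; on this read-out higher numbers stand for weaker inhibition and lower numbers for stronger inhibition.
Compound 2 `O=C(NNC(=O)c1cccc(NS(=O)(=O)c2cnc(O)nc2O)c1)c1cccc(Cl)c1` gives 3180 nM in this assay.
Compound 3 `O=C(NNC(=O)c1ccccc1NS(=O)(=O)c1cnc(O)nc1O)c1ccccc1Cl` gives 8310 nM in this assay.

Compound 4 `O=C(NNC(=O)c1ccccc1NS(=O)(=O)c1cnc(O)nc1O)c1cccc(Cl)c1` has not yet been measured in this assay. Compound 1 and compound 2 share a core and differ in one change, (3-chlorophenyl in place of 2-chlorophenyl on a carbonyl carbon). That change gave a 1.3-fold higher number from compound 1 to compound 2 (0.13 log units; within the scatter), so by itself it left the number essentially where it was. Compound 3 carries a different core; how its core differs from that of compound 1 is not broken down here. What is known is that compound 3 sits highest of the three numbers, with compound 2 below it by a margin beyond the usual scatter and compound 1 further below still. Compound 4 is related to compound 3 by 3-chlorophenyl in place of 2-chlorophenyl on a carbonyl carbon, which is the same change that was made from compound 1 to compound 2. Because a 1.3-fold higher number from compound 1 to compound 2 (0.13 log units; within the scatter) was small, the step from compound 3 to compound 4 is expected to be similarly small, estimated at a 1.2-fold higher number from compound 3 to compound 4 (0.08 log units; within the scatter). That rests on a single earlier example on a different core, so the range kept open is wide. Compound 4 is therefore estimated at 10000 nM in this assay, expected to fall between 5000 nM and 22000 nM.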

Compound 4, half-maximal inhibitory concentration: 4420 nM
Compound 4: the middle estimate sits 2.3-fold (0.35 log units) above what was measured; the measured number lies below the stated range.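

On the core of compound 3, placing 3-chlorophenyl in place of 2-chlorophenyl on a carbonyl carbon gives a 1.9-fold lower number from compound 3 to compound 4 (0.27 log units; within the scatter) in this assay, so here too the change stays within the usual scatter of repeated measurements. Set beside the earlier step on the other core, the two results cannot be told apart: the same change on two cores in this assay, a 1.3-fold higher number (0.13 log units; within the scatter) from compound 1 to compound 2 and a 1.9-fold lower number (0.27 log units; within the scatter) from compound 3 to compound 4, 2.5-fold (0.40 log units) apart, within the scatter of two such steps. Among the compounds shown here, this shows that, on both cores tested, the change made no step large enough to read, but it does not show that the change behaves identically on the two cores, since two small steps could still hide a modest real difference, and it says nothing about any third core.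

All four compounds shown carry either 2-chlorophenyl or 3-chlorophenyl on that carbonyl carbon. From the compounds shown here alone, it remains open how the number would respond to a different group there, such as 4-chlorophenyl, an unsubstituted phenyl or a methoxyphenyl.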